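The compounds below may be only part of what the source reports. "The series", "measured", "known", "first", "only" and "open" are said of these compounds alone.

Working notes on the series. Three compounds sharing the core of compound 1, `Cc1ccc(OCC(=O)N(Cc2cccs2)CC(C)C)cc1`, have been run in an assay on HEK293 cells for agonist activity at transient receptor potential cation channel subfamily M member 8 (Homo sapiens), read by fluorescence and calcium flux, with a stated time of 15 min; a lower number here means that less compound is needed, a higher number that more compound is needed for the effect. Compound 1 gives 900 nM. Compound 2, `CCN(Cc1c[nH]nn1)C(=O)COc1ccc(C)cc1`, gives 31100 nM. Compound 3, `CCN(Cc1cncs1)C(=O)COc1ccc(C)cc1`, gives 1100 nM. Among the measured compounds shown here, the one single-point step measured so far, a 28-fold lower number from compound 2 to compound 3 (1.45 log units; beyond the scatter), is large. Compound 3 thus stands second highest of the three numbers; compound 1 sits within the scatter of compound 3, and compound 2 lies far above it.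

Compound 4, `CCN(Cc1ccsc1)C(=O)COc1ccc(C)cc1`, is the next compound. Its change from compound 3 is thiophen-3-yl in place of 1,3-thiazol-5-yl on a saturated chain carbon bound to an amide-type nitrogen. For the measured compounds named here, the step from compound 2 to compound 3 is the only measured step touching the same place, and it shows that the five-membered ring on that saturated chain carbon can move this assay a long way. Compound 1, which also carries a ring with a single sulfur on that carbon, shows a number near that of compound 3. Compound 4 is therefore expected to give a number close to or somewhat below compound 3, with the step of a 1.6-fold lower number from compound 3 to compound 4 (0.20 log units; within the scatter) estimated to stay near the scatter. The estimate for compound 4 is 700 nM, within 250 nM to 2000 nM.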

Compound 4, half-maximal effective concentration: 88 nM
Estimate against measurement, compound 4: 8.0-fold (0.90 log units) above; the whole stated range lies above it.
By their numbers in this assay, from the lowest: compound 4; then compounds 1 and 3 (each within the scatter of the next); then compound 2.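

Among two five-membered aromatic rings with no hydrogen-bond donor, the place on a saturated chain carbon bound to an amide-type nitrogen still separates the compounds in this assay: thiophen-3-yl in place of 1,3-thiazol-5-yl gives a 13-fold lower number from compound 3 to compound 4 (1.10 log units; beyond the scatter), with 1 hetero atom in the ring instead of 2. The earlier step from the triazole to the thiazole therefore did not reach the full range at this place, which now extends to a 350-fold lower number from compound 2 to compound 4 (2.55 log units; beyond the scatter). No measured property of these compounds is at hand to account for the gap between the two rings.

From the compounds shown here alone, it remains open whether a furan-3-yl or a phenyl ring at this place would keep the number that compound 4 gives, 88 nM. Also open, going by these compounds, is how a methyl group, a chlorine atom or an amine on the thiophen-3-yl ring would move it.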